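Swapping the amide aryl group on a shared core

A few compounds are considered here, and "the series" means these few. Any claim that something is new, unique, unknown or untested is made for them only; others in the source may bear on it.

Compound 1, `O=C(Nc1ccc(Cl)c(-c2nnc3c(Cl)cccn23)c1)c1ccc(C(F)(F)F)cc1Cl`: > 100000 nM, a limit of the assay
Compound 2, `Cc1nc(C(=O)Nc2ccc(Cl)c(-c3nnc4c(Cl)cccn34)c2)cs1`: > 100000 nM, a limit of the assay
Compound 3, `O=C(Nc1ccc(Cl)c(-c2nnc3c(Cl)cccn23)c1)c1ccc(C(F)(F)F)cc1F`: > 100000 nM, a limit of the assay

The three measured compounds were all tested in a functional assay on A549 cells (Homo sapiens) for antiproliferative activity, read by MTT assay, with a stated time of 72 h; a higher number here means a weaker inhibitor, a lower number a stronger inhibitor. Compound 2 stands at the upper limit of this assay, so its actual value is not known. The same is true of the others, as summed up by the limit of > 100000 nM in this assay, at which 3 of the 3 values shown sit. Among the compounds with values here, the only one-point step among the measured compounds, a step that the two limits leave unreadable from compound 1 to compound 3, cannot be read for that reason.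

Compound 4, `CS(=O)(=O)c1ccc(C(=O)Nc2ccc(Cl)c(-c3nnc4c(Cl)cccn34)c2)cc1`, differs from compound 2 by 4-(methylsulfonyl)phenyl in place of 2-methyl-1,3-thiazol-4-yl on a carbonyl carbon. Within the data shown here, no measured step resembles this change, and nothing among the known values points in either direction. The step from compound 2 to compound 4 is therefore expected to be a number no higher from compound 2 to compound 4 (the limit leaves the size open), with the outcome most likely another limit. Compound 4 is estimated at 100000 nM in this assay, with a range from 30000 nM to 300000 nM.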

Compound 4, half-maximal inhibitory concentration: > 100000 nM
Compound 4 was reported as a limit (the forecaster's own chance of this, stated with the estimate: 75%); the middle value sits exactly at the limit.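

Within the data shown here, compound 2 and compound 4 are both reported only as limits of the assay, so no step between them can be read: the limit of > 100000 nM in this assay, at which 4 of the 4 values shown sit.

The compounds shown leave open how strongly any of them acts in this assay, and whether changing the amide aryl group on the shared core alters that at all.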